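Changing the end group at a carbonyl carbon

A few compounds are considered here, and "the series" means these few. Any claim that something is new, unique, unknown or untested is made for them only; others in the source may bear on it.

Measured so far in a functional assay on HEK293 cells for agonist activity at Vasopressin V2 receptor (Homo sapiens), read by a luciferase reporter and cAMP accumulation; a higher number here means that more compound is needed for the effect, a lower number that less compound is needed:
compound 1 `CCOC(=O)CNC(=O)NCc1ccc(C(=O)N2CCCCc3ccccc32)cc1C` gives 140 nM
compound 2 `Cc1cc(C(=O)N2CCCCc3ccccc32)ccc1CNC(=O)NCC(=O)OC(C)(C)C` gives 120 nM
compound 3 `Cc1cc(C(=O)N2CCCCc3ccccc32)ccc1CNC(=O)NCC(=O)N1CCCCC1` gives 150 nM

Compound 3 sits within the scatter of both of the others: a 1.1-fold higher number from compound 1 to compound 3 (0.03 log units; within the scatter) and a 1.3-fold higher number from compound 2 to compound 3 (0.10 log units; within the scatter). The three compounds share one core and differ only in the group carried on a carbonyl carbon at one end of the molecule. Compound 4 `COC(=O)[C@@H]1CCCN1C(=O)NCc1ccc(C(=O)N2CCCCc3ccccc32)cc1C` changes that same region more deeply: 2-(methoxycarbonyl)pyrrolidin-1-yl in place of (((piperidin-1-yl)carbonyl)methyl)amino on a carbonyl carbon. The measured steps that bear on this are the three among the measured compounds: a 1.2-fold lower number from compound 1 to compound 2 (0.07 log units; within the scatter), together with the two steps to compound 3 just named, each within the scatter. Among the compounds with values here, no measured pair shows that altering this end of the molecule moves the number in this assay beyond the scatter, although none of those pairs places a ring on that carbonyl carbon as compound 4 does, so the change is of a somewhat different kind from those already seen. The expectation for compound 4 is therefore no step beyond the scatter, no change at the digits printed from compound 3 to compound 4 (within the scatter), with a wider range to allow for the untested type of change. Compound 4 is estimated at 150 nM, between 50 nM and 450 nM.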

Compound 4, half-maximal effective concentration: 100 nM
For compound 4 the middle estimate is 1.5-fold (0.18 log units) above the measured one; the range from low to high includes it.
By their numbers in this assay, from the lowest: compounds 4, 2, 1 and 3 (each within the scatter of the next).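

In this assay, a ring now sits on the carbonyl carbon, and the number stays close to those of all three earlier compounds: a 1.5-fold lower number from compound 3 to compound 4 (0.18 log units; within the scatter) and a 1.2-fold lower number from compound 2 to compound 4 (0.08 log units; within the scatter) and also a 1.4-fold lower number from compound 1 to compound 4 (0.15 log units; within the scatter) are the steps. Within the data shown here, this extends what the earlier compounds showed, since their end groups were all open chains carrying a hydrogen-bond donor, whereas 2-(methoxycarbonyl)pyrrolidin-1-yl brings a five-membered non-aromatic ring and a defined stereocentre, has no hydrogen-bond donor, and still gives no step beyond the scatter. Nothing available explains why this end of the molecule can change so much with so little effect on the number.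

Going by these compounds, it remains open whether the mirror-image form of compound 4 would give a similar number, since the stereocentre has been seen in one form only. On these data alone, it is equally open whether a free carboxylic acid in place of the methyl ester, or a primary amine at this end, would finally produce a step beyond the scatter.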